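Triazole thioether series: propoxy to isobutoxy at the limit

The compounds below may be only part of what the source reports. "The series", "measured", "known", "first", "only" and "open" are said of these compounds alone.

Measured in an assay on isolated protein (Mus musculus) for inhibition of IL15-IL15 receptor (Homo sapiens), read by resazurin assay, with stated times of 30 min and 2.5 days; on this read-out lower numbers stand for stronger inhibition and higher numbers for weaker inhibition:
compound 1, `Cn1c(Cc2nn(C)c(=O)c3ccccc23)nnc1SCCCCCCCCCCCCCCCC(=O)Nc1ccc(Cl)cc1Cl`: 7300 nM
compound 2, `CCCOc1ccc(NC(=O)CSc2nnc(Cc3nn(C)c(=O)c4ccccc34)n2C)cc1`: a limit of the assay, > 30000 nM
compound 3, `Cn1c(Cc2nn(C)c(=O)c3ccccc23)nnc1SCCCCCCCC(=O)Nc1ccc(I)cc1`: 1300 nM

Compound 2 stands apart from the other two in that this assay returns for it no number but a limit, as stated in the limit of > 30000 nM in this assay, at which 1 of the 3 values shown sits. Compound 1 and compound 3 both give numbers, with compound 3 the lower of the two; they differ from compound 2 in several places at once, so the three values are read side by side and not as steps. Within the data shown here, no pair among the measured compounds differs in one place, and no measured step exists in this assay.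

Compound 4, `CC(C)COc1ccc(NC(=O)CSc2nnc(Cc3nn(C)c(=O)c4ccccc34)n2C)cc1`, differs from compound 2 by methyl in place of hydrogen on a saturated chain carbon bound to two saturated chain carbons. The change adds one carbon on the saturated chain and leaves the shared core, the thioether link, the amide and the aryl ring as they stand in compound 2. Among the measured compounds shown here, nothing among the measured compounds speaks for a shift beyond the scatter from such a change, so the step from compound 2 to compound 4 is expected to be none beyond the scatter, and the estimated step is a number no higher from compound 2 to compound 4 (the limit leaves the size open). For compound 4 the expected value in this assay is 30000 nM, within 10000 nM to 100000 nM, with the assay most likely again returning only a limit.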

Compound 4, half-maximal inhibitory concentration: 30000 nM
Compound 4: middle estimate and measured number agree at the digits printed; the range from low to high includes it.
By their numbers in this assay, from the lowest: compound 3; then compound 1; then compound 4.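

In this assay compound 4 gives 30000 nM, so the isobutoxy compound returns a number, though one at the very top of the range tested. Methyl in place of hydrogen on a saturated chain carbon bound to two saturated chain carbons gives a number no higher from compound 2 to compound 4 (the limit leaves the size open). Compound 2 gives > 30000 nM, which is a limit of the assay and not a number. The size of the change from propoxy to isobutoxy therefore cannot be read, because one end of the pair is that limit: the limit of > 30000 nM in this assay, at which 1 of the 4 values shown sits.

On these data alone, it remains open whether a longer chain on the ether oxygen, such as hexyloxy, or an amine at the end of that chain would bring this pair's short thioether amide clearly into the measurable range. Compound 1 and compound 3 differ from this pair in several places at once, so their numbers cannot be assigned to the longer chain between the thioether and the amide or to the chlorine and iodine on the aryl ring.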